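The compounds below may be only part of what the source reports. "The series", "measured", "known", "first", "only" and "open" are said of these compounds alone.

Measured compounds:
Compound 1 `COc1cc(-c2nn(-c3cccc(NC(=O)c4ccc(Cl)c(C(F)(F)F)c4)c3)cc2-c2ccncc2)ccc1Cl`, which in a functional assay on OVCAR-4 cells (Homo sapiens) for inhibition, read by sulforhodamine B assay, with a stated time of 48 h (on this read-out higher numbers stand for weaker inhibition of growth and lower numbers for stronger inhibition of growth), gives 8040 nM.
Compound 2 `O=C(Nc1cccc(-n2cc(-c3ccncc3)c(-c3ccc(Cl)c(O)c3)n2)c1)Nc1ccc(Cl)c(C(F)(F)F)c1`, which in this assay gives 1200 nM.

Compound 1 stands highest of the two numbers; compound 2 gives a lower number, and the gap lies beyond the scatter. The two also differ in more than one place, so the separate contribution of the urea linkage is not isolated by any single step. Compound 3 `COc1cc(-c2nn(-c3cccc(NC(=O)Nc4ccc(Cl)c(Cl)c4)c3)cc2-c2ccncc2)ccc1Cl` is not yet measured. It differs from compound 1 in one place: (3,4-dichlorophenyl)amino in place of 4-chloro-3-(trifluoromethyl)phenyl on a carbonyl carbon. Compound 3 thus carries a urea linkage as compound 2 does, while keeping the rest of compound 1. A step toward a lower number is expected, moderate in size, because compound 2 gives 1200 nM. The step from compound 1 to compound 3 is expected to be a 2.7-fold lower number from compound 1 to compound 3 (0.43 log units; beyond the scatter). Compound 3 is expected to give 3000 nM, within 1000 nM to 9000 nM.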

Compound 3, concentration for 50% growth inhibition: 1290 nM
The estimate for compound 3 lay 2.3-fold (0.37 log units) above the measured number; measured number inside the range.
By their numbers in this assay, from the lowest: compounds 2 and 3 (each within the scatter of the next); then compound 1.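

In this assay the swap of 4-chloro-3-(trifluoromethyl)phenyl for (3,4-dichlorophenyl)amino on the carbonyl carbon gives a 6.2-fold lower number from compound 1 to compound 3 (0.79 log units; beyond the scatter) and so shows, in a single step on the core of compound 1, that this position responds to the change. The step bundles two changes: the entering group brings a nitrogen with one hydrogen-bond donor, turning the amide-type linkage into a urea, and the trifluoromethyl group is gone, leaving two chlorines on the ring. Nothing measured here bears on why the number falls.

The compounds shown leave open how much of the step belongs to the new nitrogen and how much to the change of ring substituents. A plain 3,4-dichlorophenyl on the carbonyl carbon, or a methylene in place of the amino nitrogen, would address that question.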